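This account rests on a few compounds, and the source may have more. Where it says the series, first, only, none or still open, it means among the compounds named here.

Measured so far in an ADME assay on Huh-7 cells (Homo sapiens) for cytotoxicity, read by MTT assay, with a stated time of 72 h; on this read-out higher numbers stand for lower toxicity in this test and lower numbers for higher toxicity in this test:
compound 1, `O=C(NO)c1ccccc1Cl`: 330000 nM
compound 2, `O=C(NO)c1ccccc1Br`: 270000 nM
compound 3, `O=C(NO)c1cccc(Cl)c1`: 120000 nM

Compound 1 and compound 2 share a core and differ by one change, (bromo in place of chloro on an aromatic carbon), which gave a 1.2-fold lower number from compound 1 to compound 2 (0.09 log units; within the scatter). Compound 3 carries the same atoms joined differently; the difference between the two cores is not broken down here. In this assay compound 3 gives the lowest number of the three, and its steps to compound 2 and to compound 1 are both beyond the scatter.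

Compound 4, `O=C(NO)c1cccc(Br)c1`, is not yet measured. It differs from compound 3 by bromo in place of chloro on an aromatic carbon. Going by the values given here, this is the same kind of change as the one from compound 1 to compound 2, though not the same: there the bromo entered ortho to a group of 4 heavy atoms, here it enters meta to a group of 4 heavy atoms. Since the earlier step, a 1.2-fold lower number from compound 1 to compound 2 (0.09 log units; within the scatter), stayed within the scatter, a step of similar size is expected for compound 4, namely a 1.2-fold lower number from compound 3 to compound 4 (0.08 log units; within the scatter), resting on that single precedent. Compound 4 is therefore estimated at 100000 nM, with a range from 50000 nM to 200000 nM.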

Compound 4, half-maximal cytotoxic concentration: 310000 nM
Compound 4: the middle estimate sits 3.1-fold (0.49 log units) below what was measured; measured number outside the range, above it.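

In this assay, bromo in place of chloro on an aromatic carbon, meta to a group of 4 heavy atoms, gave a 2.6-fold higher number from compound 3 to compound 4 (0.41 log units; beyond the scatter), so a step that stayed within the scatter on the core of compound 1 did not stay there on the core of compound 3. Set side by side, the two outcomes show that this change cannot simply be carried from one core to the other in this series: the same change on two cores in this assay, a 1.2-fold lower number (0.09 log units; within the scatter) from compound 1 to compound 2 and a 2.6-fold higher number (0.41 log units; beyond the scatter) from compound 3 to compound 4, 3.2-fold (0.50 log units) apart, beyond the scatter of two such steps What this does not show is why the two steps differ, and two steps give no rule for how the change would behave on any further core.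

From the compounds shown here alone, it remains open how a fluoro, a methoxy or an amine in the same place would read in this assay. Going by these compounds, it is also open whether the gap between the two steps would persist if a carboxylic acid replaced the group of 4 heavy atoms.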